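Replacing Diethylamino with Methylpiperazinyl: Expected Cytotoxicity

The source may report more compounds than this note shows. Statements on the series, on what has been measured and on what is new or still open speak of the compounds shown alone.

Measured in an ADME assay on cells (Homo sapiens) for cytotoxicity, read by sulforhodamine B assay, with a stated time of 48 h; a higher number here means that more compound is needed for the effect, a lower number that less compound is needed:
Compound 1 `CN1CCN(c2ccc(/C=C3/SC(Nc4ccccc4)=NC3=O)cc2)CC1`: 6400 nM
Compound 2 `CN(C)c1ccc(/C=C2/SC(N(c3ccccc3)c3ccccc3)=NC2=O)cc1`: > 100000 nM
Compound 3 `CCN(CC)c1ccc(/C=C2/SC(N(c3ccccc3)c3ccccc3)=NC2=O)cc1`: > 100000 nM

Compound 3 stands at a limit of this assay rather than at a number, so its reading is a boundary and nothing more. Compound 2 sits at the same limit, which is described by the limit of > 100000 nM in this assay, at which 2 of the 3 values shown sit. Because both ends are limits, the change from dimethylamino to diethylamino, a step that the two limits leave unreadable from compound 2 to compound 3, cannot be sized. For the measured compounds named here, compound 1, which carries the 4-methylpiperazin-1-yl group but only one phenyl on its amine nitrogen, gives a measured number in this assay, 6400 nM; no single-change step links it to the new compound, so its value merely shows that this group can sit on a compound that does produce a reading.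

Compound 4 `CN1CCN(c2ccc(/C=C3/SC(N(c4ccccc4)c4ccccc4)=NC3=O)cc2)CC1` differs from compound 3 by 4-methylpiperazin-1-yl in place of diethylamino on an aromatic carbon. Going by the values given here, the only measured step on this side of the series is unreadable, so it offers no size to carry forward. Compound 4 is therefore expected to remain near or at the limit, giving an estimate of 80000 nM with a range from 20000 nM to 300000 nM. The expected step from compound 3 to compound 4 is an at least 1.2-fold lower number from compound 3 to compound 4 (0.09 log units; that floor lies within the scatter).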

Compound 4, half-maximal effective concentration: > 100000 nM
Compound 4 gave a limit, no number; the forecaster's own chance of this, stated with the estimate: 55%; middle value at least 1.2-fold (0.09 log units) from the limit.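

In this assay, dimethylamino, diethylamino and 4-methylpiperazin-1-yl on the aromatic carbon all leave the reading at the same boundary, so the steps among compound 2, compound 3 and compound 4 cannot be read: the limit of > 100000 nM in this assay, at which 3 of the 4 values shown sit.

For the compounds shown here, the one readable comparison holds the 4-methylpiperazin-1-yl group fixed and changes only the amine nitrogen, where phenyl in place of hydrogen gives an at least 15-fold higher number from compound 1 to compound 4 (1.19 log units; beyond the scatter), a large step. Among these compounds, then, the measured reading of compound 1 goes with the hydrogen on that nitrogen and not with the 4-methylpiperazin-1-yl group alone, since compound 4 carries that group too and gives only a limit.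

The compounds shown leave open whether a smaller group on that nitrogen, such as a methyl in place of the second phenyl, would still reach the limit, and how far past it compound 2, compound 3 and compound 4 really lie. They also leave open whether a morpholine ring on the aromatic carbon, paired with the hydrogen on the nitrogen, would give a number as compound 1 does.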